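The source may report more compounds than this note shows. Statements on the series, on what has been measured and on what is new or still open speak of the compounds shown alone.

Compound 3 `N#Cc1ccc(Cn2cncc2CNc2ccc(C(=O)NCC3CCCCC3)c(-c3ccccc3)c2)cc1` is one of three analogues measured in a functional assay on NIH3T3 cells (Mus musculus) (a lower number here means that less compound is needed, a higher number that more compound is needed for the effect), and in that assay compound 3 gives only a limit, > 10 uM. Compound 1 `CC(C)NC(=O)c1ccc(NCc2cncn2Cc2ccc(C#N)cc2)cc1-c1ccccc1`, which carries an isopropyl group on the amide-type nitrogen, likewise returns a limit of > 10 uM in this assay. The step from compound 1 to compound 3, a step that the two limits leave unreadable from compound 1 to compound 3, is therefore of unknown size. Compound 2 `COC(=O)[C@H](CCSC)NC(=O)c1ccc(NCc2cncn2Cc2cccc(C#N)c2)cc1-c1ccccc1`, in which the nitrile sits on a different position of the benzyl ring, also gives only a limit of > 10 uM in this assay. All three values share one feature: the limit of > 10 uM in this assay, at which 3 of the 3 values shown sit.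

Compound 4 `COC(=O)[C@H](CCSC)NC(=O)c1ccc(NCc2cncn2Cc2ccc(C#N)cc2)cc1-c1ccccc1` differs from compound 3 by a single change, (1-(methoxycarbonyl)-3-(methylsulfanyl)propyl in place of cyclohexylmethyl on an amide-type nitrogen). Among the measured compounds shown here, no measured step reads on this change, since the only step available is unreadable. With every measured value sitting at the limit, compound 4 is expected to do the same, and the estimated step from compound 3 to compound 4, a step that the limit leaves unreadable from compound 3 to compound 4, is expected to be none beyond the scatter. The estimate for compound 4 in this assay is 15 uM, with a range from 5 uM to 50 uM.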

Compound 4, concentration for half-maximal effect: > 10 uM
Compound 4: only a limit was reported (the forecaster's own chance of this, stated with the estimate: 85%); the middle value does not contradict the limit.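

In this assay, among the compounds shown here, compound 4 gives only the limit > 10 uM and so no step from compound 1, compound 2 or compound 3 to compound 4 can be read. The compounds shown leave open how far any of these changes moves the value, since all share one result: the limit of > 10 uM in this assay, at which 4 of the 4 values shown sit.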